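Ortho-Bromo on the Anilide: an Expected Cytotoxicity Step

The source may report more compounds than this note shows. Statements on the series, on what has been measured and on what is new or still open speak of the compounds shown alone.

Compound 2 `O=C(CSc1snnc1-c1ccc(Br)cc1Br)Nc1ccccc1` carries the shared core with a plain anilide at the amide nitrogen. In an ADME assay on MT4 cells (Homo sapiens) for cytotoxicity, read by MTT assay, with a stated time of 5 days (on this read-out lower numbers stand for higher toxicity in this test and higher numbers for lower toxicity in this test), compound 2 gives 24800 nM. Among the two measured compounds this is the only actual number, so compound 2 stands alone as the reference point. Compound 1 `Cc1ccc(NC(=O)CSc2snnc2-c2ccc(Br)cc2Br)c([N+](=O)[O-])c1` bears a methyl and a nitro group on its anilide ring, and in this assay compound 1 gives > 229000 nM, which is a limit of the assay rather than a number; compound 1 therefore sits at the limit of > 229000 nM in this assay, at which 1 of the 2 values shown sits.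

Compound 3 `O=C(CSc1snnc1-c1ccc(Br)cc1Br)Nc1ccccc1Br` is the untested analogue of compound 2, and the two differ in one place: bromo in place of hydrogen on an aromatic carbon. Going by the values given here, no pair of measured compounds in this set shares that change, so its size is not known from the data. A single bromo entering the anilide ring is a modest alteration, and the step from compound 2 to compound 3 is expected to be a 1.4-fold lower number from compound 2 to compound 3 (0.14 log units; within the scatter), within or just beyond the scatter, if anything toward higher toxicity. Compound 3 is therefore estimated at 18000 nM, with a range from 7000 nM to 50000 nM.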

Compound 3, half-maximal cytotoxic concentration: > 221000 nM
Compound 3 ended at the assay's limit; the forecaster's own chance of this, stated with the estimate: 10%; middle value at least 12-fold (1.08 log units) from the limit.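

Bromo in place of hydrogen on an aromatic carbon of the anilide ring, ortho to a large group, is a change of real size in this assay: the read-out gives an at least 8.9-fold higher number from compound 2 to compound 3 (0.94 log units; beyond the scatter), toward lower toxicity in this test. Going by these compounds alone, this is the first step that can be read at all, and it shows that this one place on the anilide ring, changed by a single heavy atom, can carry the compound from a measured number to the end of the assay's range. Compound 3 gives a limit of the assay and not a number: the limit of > 221000 nM in this assay, at which 1 of the 3 values shown sits.

The compounds shown leave open whether this step belongs to bromo alone, or whether a chloro, a methyl or a methoxy group at the same place would give a step of similar size. Within the data shown here, the full size of the step from the plain anilide also stays open, and compound 2 remains the only compound here with an actual number.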